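From 4-methoxyphenyl to naphthalen-1-yl on compound 2

The source may report more compounds than this note shows. Statements on the series, on what has been measured and on what is new or still open speak of the compounds shown alone.

In a functional assay on HL-60 cells (Homo sapiens) for inhibition, read by CCK-8 assay, with a stated time of 48 h, tested at 20 uM (a higher number here means more inhibition of growth at the concentration tested, a lower number less inhibition of growth), compound 1 (`COc1ccc(Cc2nnc(NC(=O)/C(C#N)=C/c3ccccc3OS(=O)(=O)c3ccc([N+](=O)[O-])cc3)s2)cc1`) stands at 51% and compound 2 (`COc1ccc(Cc2nnc(NC(=O)/C(C#N)=C/c3ccccc3OS(=O)(=O)c3ccccc3[N+](=O)[O-])s2)cc1`) at 25% as the lower of the two numbers. Compound 3 (`N#C/C(=C\c1ccccc1OS(=O)(=O)c1ccccc1[N+](=O)[O-])C(=O)Nc1nnc(Cc2cccc3ccccc23)s1`) differs from compound 2 by one change (naphthalen-1-yl in place of 4-methoxyphenyl on a saturated chain carbon bound to an aromatic carbon): naphthalen-1-yl in place of 4-methoxyphenyl on a saturated chain carbon bound to an aromatic carbon. Going by the values given here, the only measured step (a number 26 percentage points lower from compound 1 to compound 2 (beyond the scatter)) lies on a sulfonyl sulfur and not at this place. It shows only that the read-out can move beyond the scatter. Among the compounds with values here, no measured step covers this change, so only a small upward step is expected (a number 7 percentage points higher from compound 2 to compound 3 (within the scatter)). In this assay the estimate for compound 3 is 32% (expected range 14% to 55%).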

Compound 3, percent growth inhibition at one concentration: 23%
Compound 3: middle estimate off by 9 percentage points, on the high side; the range from low to high includes it.
By their numbers in this assay, from the lowest: compounds 3 and 2 (each within the scatter of the next); then compound 1.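

In this assay, naphthalen-1-yl in place of 4-methoxyphenyl on a saturated chain carbon bound to an aromatic carbon gives a number 2 percentage points lower from compound 2 to compound 3 (within the scatter) with the 2-nitrophenyl group on the sulfonyl sulfur held fixed. At this place, then, a second six-membered aromatic ring and the loss of the methoxy oxygen leave the read-out within the scatter. Nothing available explains this result.

As far as these compounds go, whether the same change holds alongside the 4-nitrophenyl group of compound 1 remains open. Also open, from the compounds shown here alone, is what an amine, a carboxylic acid or a longer chain would give at this place.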